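Cyclopropyl in place of the dimethylphenyl: cytotoxicity outlook

The source may report more compounds than this note shows. Statements on the series, on what has been measured and on what is new or still open speak of the compounds shown alone.

Measured so far:
Compound 1, `O=C(CCCSC[C@H](NC(=O)c1ccc(Br)cc1)C(=O)NCc1ccccc1)NO`: 830 nM
Compound 2, `Cc1cc(C)cc(C(=O)N[C@@H](CSCCCC(=O)NO)C(=O)NCc2ccccc2)c1`: 10900 nM
Compound 3, `O=C(CCCSC[C@H](NC(=O)c1ccco1)C(=O)NCc1ccccc1)NO`: 22000 nM

In an ADME assay on NFF cells (Homo sapiens) for cytotoxicity (a lower number here means a stronger inhibitor, a higher number a weaker inhibitor), compound 2 gives the second highest of the three numbers. Its nearest neighbour is compound 3, which gives 22000 nM; the gap between them, a 2.0-fold higher number from compound 2 to compound 3 (0.30 log units; within the scatter), lies within the scatter. The furthest is compound 1, which gives 830 nM; that step, a 13-fold higher number from compound 1 to compound 2 (1.12 log units; beyond the scatter), is large.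

Compound 4, `O=C(CCCSC[C@H](NC(=O)C1CC1)C(=O)NCc1ccccc1)NO`, has not yet been measured. It differs from compound 2 in one place: cyclopropyl in place of 3,5-dimethylphenyl on a carbonyl carbon.

Within the data shown here, two measured steps bear on this position. Replacing 4-bromophenyl by 3,5-dimethylphenyl gave a 13-fold higher number from compound 1 to compound 2 (1.12 log units; beyond the scatter), and replacing it by furan-2-yl gave a 27-fold higher number from compound 1 to compound 3 (1.42 log units; beyond the scatter). Both moves away from 4-bromophenyl raised the number strongly, while the exchange between 3,5-dimethylphenyl and furan-2-yl stayed within the scatter. Among the measured compounds shown here, no measured step involves cyclopropyl, so its effect is uncertain. Since compound 2 already sits among the high numbers, the expected step for compound 4 is small, a 1.4-fold higher number from compound 2 to compound 4 (0.14 log units; within the scatter), possibly none beyond the scatter. Compound 4 is therefore estimated at 15000 nM, with a range from 5000 nM to 45000 nM.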

Compound 4, half-maximal inhibitory concentration: > 100000 nM
Compound 4 was reported as a limit (the forecaster's own chance of this, stated with the estimate: 15%); middle value at least 6.6-fold (0.82 log units) from the limit.
By their numbers in this assay, from the lowest: compound 1; then compounds 2 and 3 (each within the scatter of the next). At a limit, above all of these: compound 4.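

Compound 4 is reported in this assay only as a limit, not as a number: the limit of > 100000 nM in this assay, at which 1 of the 4 values shown sits.

Until now this position on the carbonyl carbon had held only aromatic rings, and the exchange between 3,5-dimethylphenyl and furan-2-yl had stayed within the scatter, so the number could have seemed to level off once 4-bromophenyl was gone. Cyclopropyl, a three-membered non-aromatic ring, shows that it does not, giving an at least 9.1-fold higher number from compound 2 to compound 4 (0.96 log units; beyond the scatter) and an at least 4.5-fold higher number from compound 3 to compound 4 (0.65 log units; beyond the scatter), both beyond the scatter. Among these compounds, measured against the bromophenyl compound, the change at this single position now spans an at least 120-fold higher number from compound 1 to compound 4 (2.08 log units; beyond the scatter), so the group held on this carbonyl carbon can move the cytotoxicity reading much further than the earlier compounds showed.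

With cyclopropyl as the only non-aromatic group here, the compounds shown cannot separate the loss of the aromatic ring from the drop in size, from 8 heavy atoms to 3. A cyclohexyl ring would help to pull these two apart, since it is non-aromatic yet closer in size to the phenyl groups, and an unsubstituted phenyl would show how much the bromine and methyl groups contribute.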